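Trading the Catechol-like Ring for a Nitrophenyl

This account rests on a few compounds, and the source may have more. Where it says the series, first, only, none or still open, it means among the compounds named here.

Compound 2 `COc1cc(-c2cc(-c3cc(C(C)C)c(O)cc3C)[nH]c(=O)c2C#N)ccc1O` was tested in a functional assay for inhibition, tested at 60 ug/mL (a lower number here means a weaker effect, a higher number a stronger effect of the compound at the concentration tested), and gave 37.5%. That is the lowest of the three numbers measured: compound 1 `COc1ccc(-c2cc(-c3cc(C(C)C)c(O)cc3C)[nH]c(=O)c2C#N)c(OC)c1` gave 48.5%, and compound 3 `COc1cc(OC)c(-c2cc(-c3cc(C(C)C)c(O)cc3C)[nH]c(=O)c2C#N)c(OC)c1` gave 66%. The step of a number 11 percentage points lower from compound 1 to compound 2 (beyond the scatter) and the step of a number 17.5 percentage points higher from compound 1 to compound 3 (beyond the scatter) both show that the aryl ring on the shared core matters, with the methoxy-rich rings of compound 1 and compound 3 ahead of the 4-hydroxy-3-methoxyphenyl of compound 2.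

Compound 4 `Cc1cc(O)c(C(C)C)cc1-c1cc(-c2ccccc2[N+](=O)[O-])c(C#N)c(=O)[nH]1` differs from compound 2 in exactly that ring: 2-nitrophenyl in place of 4-hydroxy-3-methoxyphenyl on an aromatic carbon. Neither measured step involves a nitro group, so the change is outside what has been seen, and only the spread among compound 1, compound 2 and compound 3 gives a sense of scale. Since compound 2 sits at the bottom and the other aryl variants landed higher, a modest rise is expected, with wide uncertainty, the step of a number 7.5 percentage points higher from compound 2 to compound 4 (within the scatter) being the estimate. Compound 4 is therefore expected to show about 45%, in a range from 20% to 70% in this assay.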

Compound 4, a percentage reported as inhibition, at one concentration (the size of the read-out at that concentration, not a potency): 31%
The estimate for compound 4 lay 14 percentage points above the measured number, and the stated range covers the measured number.
By their numbers in this assay, from the lowest: compounds 4 and 2 (each within the scatter of the next); then compound 1; then compound 3.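

In this assay, replacing the 4-hydroxy-3-methoxyphenyl with 2-nitrophenyl gave a number 6.5 percentage points lower from compound 2 to compound 4 (within the scatter), so at this position, ortho to the cyano group, a ring without a hydrogen-bond donor could not be told apart from the ring of compound 2. Replacing the 2,4-dimethoxyphenyl with the same 2-nitrophenyl gave a number 17.5 percentage points lower from compound 1 to compound 4 (beyond the scatter), which shows that these two rings are not interchangeable here, even though both names carry a group at the 2-position. Nothing measured on these compounds explains either step.

The compounds shown leave open whether an amine or a carboxylic acid in place of the nitro group would stay level with compound 4 or move toward compound 3. They also leave open how a nitro group would read at another place on this ring.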